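A few compounds are considered here, and "the series" means these few. Any claim that something is new, unique, unknown or untested is made for them only; others in the source may bear on it.

Measured so far in a functional assay on HT-1080 cells (Homo sapiens) for antiproliferative activity, read by sulforhodamine B assay, with a stated time of 48 h; a higher number here means a weaker inhibitor, a lower number a stronger inhibitor:
Compound 1, `CCC(=O)Nc1cccc(S(=O)(=O)Oc2ccccc2C(C)C)c1`: 12000 nM
Compound 2, `CCCC(=O)Nc1cccc(S(=O)(=O)Oc2ccccc2C(C)C)c1`: 15000 nM
Compound 3, `CCC(=O)Nc1ccc(S(=O)(=O)Oc2ccccc2C(C)C)cc1`: 2100 nM

Compounds 1 and 2 share one core, compound 3 another; the difference between the two cores is not broken down here. Within the first core, the change from compound 1 to compound 2 is methyl in place of hydrogen on a saturated chain carbon, two bonds along the chain from a carbonyl carbon, and it gave a 1.3-fold higher number from compound 1 to compound 2 (0.10 log units; within the scatter). Compound 3 stands apart from both, with a number in this assay that is beyond the scatter from compound 1 and from compound 2.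

Compound 4, `CCCC(=O)Nc1ccc(S(=O)(=O)Oc2ccccc2C(C)C)cc1`, is not yet measured. It differs from compound 3 by methyl in place of hydrogen on a saturated chain carbon, two bonds along the chain from a carbonyl carbon, which is the same change as that made from compound 1 to compound 2, in the same place, on the other core. Among the compounds with values here, the only evidence for this change is the single step from compound 1 to compound 2, so the step from compound 3 to compound 4 is expected to be of like size, a 1.3-fold higher number from compound 3 to compound 4 (0.11 log units; within the scatter), an expectation that rests on a 1.3-fold higher number from compound 1 to compound 2 (0.10 log units; within the scatter). On that basis compound 4 is expected to give about 2700 nM in this assay.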

Compound 4, half-maximal inhibitory concentration: 950 nM
Beside the measured number, compound 4's estimate is 2.8-fold (0.45 log units) above it; the whole stated range lies above it.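

In this assay, methyl in place of hydrogen on a saturated chain carbon, two bonds along the chain from a carbonyl carbon, gave a 2.2-fold lower number from compound 3 to compound 4 (0.34 log units; beyond the scatter) and so did not carry over unchanged from the core of compound 1 to the core of compound 3: the same change on two cores in this assay, a 1.3-fold higher number (0.10 log units; within the scatter) from compound 1 to compound 2 and a 2.2-fold lower number (0.34 log units; beyond the scatter) from compound 3 to compound 4, 2.8-fold (0.44 log units) apart, beyond the scatter of two such steps
The same change therefore cannot be assumed to transfer between these two cores, since it registers on the core of compound 3 but stays within the scatter on the core of compound 1. This rests on a single pair of steps, and it does not show why the cores differ or how the change would behave on any further core.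

Open, as far as these compounds go, is whether a longer chain, a branched chain or a chain ending in an amine would extend the step seen on the core of compound 3. Also open, from the compounds shown here alone, is whether any such group would register on the core of compound 1.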